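A few compounds are considered here, and "the series" means these few. Any claim that something is new, unique, unknown or untested is made for them only; others in the source may bear on it.

Compound 1 `O=C(NCc1ccc(S(=O)(=O)c2ccccc2)cc1)N1Cc2ccncc2C1` is the parent of this small set. In a physicochemical assay for solubility, in phosphate buffer, with a stated time of 24 h, at pH 7.4, tested at 100 uM (a higher number here means a more soluble compound, a lower number a less soluble compound), compound 1 gives 115000 nM, the lowest of the three numbers recorded. Compound 2 `CCC(=O)N1CCC(S(=O)(=O)c2ccc(CNC(=O)N3Cc4ccncc4C3)cc2)CC1` gives 216000 nM in this assay, and compound 3 `CN1CCC(S(=O)(=O)c2ccc(CNC(=O)N3Cc4ccncc4C3)cc2)CC1` gives 240000 nM. The step of a 1.9-fold higher number from compound 1 to compound 2 (0.27 log units; within the scatter) and the step of a 2.1-fold higher number from compound 1 to compound 3 (0.32 log units; beyond the scatter) both replace the phenyl on the sulfonyl sulfur with a saturated six-membered ring bearing a nitrogen, while the step of a 1.1-fold higher number from compound 2 to compound 3 (0.05 log units; within the scatter) shows that the group on that ring nitrogen hardly matters here.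

Compound 4 `O=C(NCc1ccc(S(=O)(=O)N2CC3(CCOCC3)C2)cc1)N1Cc2ccncc2C1` has not yet been measured in this assay. Its difference from compound 1 is a group of 9 heavy atoms (7 carbon, 1 nitrogen, 1 oxygen; one four-membered non-aromatic ring with 1 hetero atom, one six-membered non-aromatic ring with 1 hetero atom) in place of a group of 6 heavy atoms (6 carbon; one six-membered aromatic ring of carbon only), on a sulfonyl sulfur. The two steps that bear on it are those from compound 1 to compound 2 and from compound 1 to compound 3, since each also exchanges the phenyl on the sulfonyl sulfur for a non-aromatic ring with a hetero atom, and each gave a higher number of about the same modest size. The change in compound 4 brings in one hydrogen-bond acceptor, as counted above, but no charge. A step of similar size upward is therefore expected, a 1.7-fold higher number from compound 1 to compound 4 (0.24 log units; within the scatter), with no strong reason to expect more. The estimate for compound 4 in this assay is 200000 nM, with a range from 110000 nM to 350000 nM.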

Compound 4, solubility: 272000 nM
Estimate against measurement, compound 4: 1.4-fold (0.13 log units) below, and the stated range covers the measured number.
By their numbers in this assay, from the lowest: compounds 1, 2, 3 and 4 (each within the scatter of the next, the first and the last beyond it).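

In this assay, the group with a four-membered and a six-membered non-aromatic ring, each with a hetero atom, gives a 2.4-fold higher number from compound 1 to compound 4 (0.37 log units; beyond the scatter), so the gain over phenyl on the sulfonyl sulfur does not depend on a 1-substituted piperidin-4-yl group. Compound 4 cannot be told apart from either piperidine compound, with a 1.1-fold higher number from compound 3 to compound 4 (0.05 log units; within the scatter) and a 1.3-fold higher number from compound 2 to compound 4 (0.10 log units; within the scatter), so among the three non-aromatic groups shown, differing in ring make-up and in the substituent on the ring nitrogen, the number stays at one level. The step to compound 4 joins the step to compound 3 beyond the scatter, while the step to compound 2 stays within it, so the rise over phenyl is not firmly established for all three, and nothing measured here explains the rise.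

The compounds shown leave open whether a hetero atom in the group is needed at all, which a cyclohexyl on the sulfonyl sulfur would test against the same parent. They also leave open how a carboxylic acid or an open-chain amine at this place would compare with the three ring groups.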